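Fluorine added to the core of compound 1

The source may report more compounds than this note shows. Statements on the series, on what has been measured and on what is new or still open speak of the compounds shown alone.

Compound 1, `Oc1c(Br)cc(Cl)cc1-c1nc2ccccc2[nH]1`, is the starting point. In an assay for inhibition of Alpha amylase (Homo sapiens), with a stated time of 10 min (on this read-out higher numbers stand for weaker inhibition and lower numbers for stronger inhibition), compound 1 gives 2850 nM. Two other compounds share this read-out: compound 2, `COc1ccc(-c2nc3cc(C)c(C)cc3[nH]2)c(F)c1`, gives 2780 nM in this assay, and compound 3, `COc1cc(Br)c(-c2nc3cc(C)c(C)cc3[nH]2)cc1OC`, gives 1480 nM. On the numbers alone compound 1 sits at the top of the three, but its gaps to compound 2 and to compound 3 both fall within the scatter, so the three cannot be told apart.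

Compound 4, `Oc1c(Br)cc(Cl)cc1-c1nc2cc(F)ccc2[nH]1`, differs from compound 1 in one place: fluoro in place of hydrogen on an aromatic carbon. Going by the values given here, no pair of measured compounds shows such a change, so there is no measured step to lean on. The added atom is small and sits on the shared core, away from the hydroxyl- and halogen-bearing ring, so the step from compound 1 to compound 4 is expected to be no larger than the scatter, in no set direction. Compound 4 is therefore estimated at 2500 nM, in a range from 1100 nM to 5500 nM, which means an expected step of a 1.1-fold lower number from compound 1 to compound 4 (0.06 log units; within the scatter).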

Compound 4, half-maximal inhibitory concentration: 2860 nM
Beside the measured number, compound 4's estimate is 1.1-fold (0.06 log units) below it; the range from low to high includes it.
By their numbers in this assay, from the lowest: compounds 3, 2, 1 and 4 (each within the scatter of the next).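

In this assay, going by these compounds alone, fluoro in place of hydrogen on this aromatic carbon of the shared core gives a 1.0-fold higher number from compound 1 to compound 4 (0.00 log units; within the scatter) and this is the first direct comparison of two compounds that differ in one place. Within the data shown here, it shows that this position takes a fluorine with no change this read-out can detect, something the earlier compounds could not show, as no two of them differ in only one place. No measured evidence explains this result.

From the compounds shown here alone, whether a larger group, such as an amine or a carboxylic acid, on this same aromatic carbon would shift the number beyond the scatter remains open. Also open, going by these compounds, is whether fluoro here would leave the number level with other groups on the hydroxyl-bearing ring.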